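Prop-1-en-1-yl replaces ethyl at the assay limit

The source may hold more compounds than are shown below. What is called first, only, known or untested is meant among the compounds shown, and "the series" means these compounds.

Measured in an ADME assay on BaF3 cells (Mus musculus) for cytotoxicity, read by CellTiter-Glo and CCK-8 assay, with a stated time of 72 h; on this read-out higher numbers stand for weaker inhibition of growth and lower numbers for stronger inhibition of growth:
Compound 1 `C=CC(=O)N(CCN(C)C)Cc1ccc(C(=O)Nc2ccc(C)c(Nc3nccc(-c4cccnc4)n3)c2)cc1`: > 10000 nM
Compound 2 `CCC(=O)N(CCN(C)C)Cc1ccc(C(=O)Nc2ccc(C)c(Nc3nccc(-c4cccnc4)n3)c2)cc1`: > 10000 nM

Compound 2 stands at > 10000 nM, which is a limit of the assay and not a number. The vinyl group of compound 1 sits on the same carbonyl carbon, and compound 1 stands at > 10000 nM, also a limit. Both values rest on (the limit of > 10000 nM in this assay, at which 2 of the 2 values shown sit). Within the data shown here, the only measured step is a step that the two limits leave unreadable from compound 1 to compound 2, so there is no measured size to carry forward.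

Compound 3 `C/C=C/C(=O)N(CCN(C)C)Cc1ccc(C(=O)Nc2ccc(C)c(Nc3nccc(-c4cccnc4)n3)c2)cc1` differs from compound 2 in one group: prop-1-en-1-yl in place of ethyl on a carbonyl carbon. In short, prop-1-en-1-yl takes the place of ethyl on a carbonyl carbon, and the rest of the molecule stays the same. Vinyl and ethyl on this carbon both left the read-out at its limit, so a third group gives no firm reason to expect a change in either direction. Another limit is the most likely report. The expected size is a step that the limit leaves unreadable from compound 2 to compound 3, which is no step beyond the scatter. For compound 3 the estimated value is 12000 nM, with an expected range from 5000 nM to 30000 nM.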

Compound 3, concentration for 50% growth inhibition: > 10000 nM
Compound 3: a limit, no number; the forecaster's own chance of this, stated with the estimate: 85%; the middle value does not contradict the limit.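

Compound 3 gives > 10000 nM, which is a limit of the assay and not a number. Among these compounds, no step among compound 1, compound 2 and compound 3 can therefore be read: the limit of > 10000 nM in this assay, at which 3 of the 3 values shown sit. The compounds shown leave open whether vinyl, ethyl and prop-1-en-1-yl on the carbonyl carbon differ at all in their effect on growth.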